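A few compounds are considered here, and "the series" means these few. Any claim that something is new, unique, unknown or untested is made for them only; others in the source may bear on it.

Measured so far in an ADME assay on MDBK cells (Bos taurus) for cytotoxicity; on this read-out lower numbers stand for higher toxicity in this test and higher numbers for lower toxicity in this test:
- compound 1 `Fc1ccc(Cn2ccc3nc(-c4ccccc4)nc-3c2)cc1`: > 100000 nM (a limit)
- compound 2 `N#Cc1ccc(Cn2ccc3nc(-c4ccccc4)nc-3c2)cc1`: > 100000 nM (a limit)

In this assay, compound 2 stands at > 100000 nM, which is a limit and not a number. The same holds for the other measured compound: the limit of > 100000 nM in this assay, at which 2 of the 2 values shown sit. Compound 3 `FC(F)(F)c1ccc(Cn2ccc3nc(-c4ccccc4)nc-3c2)cc1` differs from compound 2 by one change: trifluoromethyl in place of cyano on an aromatic carbon. Within the data shown here, the one measured step that bears on it, a step that the two limits leave unreadable from compound 1 to compound 2, also swaps the group on that aromatic carbon, but its size cannot be read. So no step beyond the scatter is expected in this assay, and the expected step is a number no higher from compound 2 to compound 3 (the limit leaves the size open). Compound 3 is estimated at 100000 nM, with an expected range from 50000 nM to 200000 nM.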

Compound 3, half-maximal cytotoxic concentration: 84000 nM
Estimate against measurement, compound 3: 1.2-fold (0.08 log units) above; measured number inside the range.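

Among the three groups on this aromatic carbon, only trifluoromethyl, in compound 3, gives a number rather than a limit in this assay: the limit of > 100000 nM in this assay, at which 2 of the 3 values shown sit.

The steps are an at least 1.1-fold lower number from compound 2 to compound 3 (0.07 log units; that floor lies within the scatter) and an at least 1.1-fold lower number from compound 1 to compound 3 (0.07 log units; that floor lies within the scatter). Each is known only as a floor, so the compounds shown do not establish a real difference between trifluoromethyl and either cyano or fluoro here.

Going by these compounds, how an amine, a carboxylic acid or a longer chain on this aromatic carbon would read in this assay remains open. So does the effect of a change elsewhere on the shared core.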